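Allylamino analogue of compound 1: expected inhibition

A few compounds are considered here, and "the series" means these few. Any claim that something is new, unique, unknown or untested is made for them only; others in the source may bear on it.

Compound 1 `CCCNC(=C\C(=O)/C=C/c1ccc(O)c(OC)c1)/C=C/c1ccc(O)c(OC)c1` is the propylamino member of the series. In an ADME assay on Caco-2 cells (Homo sapiens) for inhibition, read by sulforhodamine B assay, with a stated time of 72 h (a lower number here means a stronger inhibitor, a higher number a weaker inhibitor), compound 1 gives only a limit of the assay, > 25000 nM. Compound 2 `CCC(C)NC(=C\C(=O)/C=C/c1ccc(OC(C)=O)c(OC)c1)/C=C/c1ccc(OC(C)=O)c(OC)c1`, the other measured member, likewise gives only a limit in this assay, > 25000 nM. Among the measured compounds shown here, both known values therefore stand at the limit of > 25000 nM in this assay, at which 2 of the 2 values shown sit, so compound 1 can be placed no more precisely than at the limit, and no measured step between compounds exists to size the effect of a change at the amine.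

Compound 3 `C=CCNC(=C\C(=O)/C=C/c1ccc(O)c(OC)c1)/C=C/c1ccc(O)c(OC)c1` differs from compound 1 by vinyl in place of ethyl on a saturated chain carbon bound to an amine nitrogen. With both measured values sitting at the limit, no step beyond the scatter is expected in this assay, in either direction. Compound 3 is expected to give about 30000 nM, within 10000 nM to 100000 nM. The step that the limit leaves unreadable from compound 1 to compound 3 is thus estimated to remain within the scatter, most likely again as a limit.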

Compound 3, half-maximal inhibitory concentration: > 25000 nM
Compound 3: only a limit was reported (the forecaster's own chance of this, stated with the estimate: 85%); the middle value lies beyond the limit too.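

No step can be read from compound 1 to compound 3 in this assay, since both values are limits of the assay: the limit of > 25000 nM in this assay, at which 3 of the 3 values shown sit.

The compounds shown leave open whether allylamino in place of propylamino changes inhibition at all in this assay, and how far any of these compounds lies beyond the limit.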